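Swapping the amide aryl for pyridin-2-yl: an expectation

This account rests on a few compounds, and the source may have more. Where it says the series, first, only, none or still open, it means among the compounds named here.

Three close relatives of one shared core have been tested in a functional assay on AN3-CA cells (Homo sapiens) for antiproliferative activity, read by MTT assay, with a stated time of 72 h; a higher number here means a weaker inhibitor, a lower number a stronger inhibitor. Compound 1 `Cc1nc(C(=O)Nc2ccc(Cl)c(-c3nnc4c(Cl)cccn34)c2)cs1` gives only a limit there, > 100000 nM. Compound 2 `O=C(Nc1ccc(Cl)c(-c2nnc3c(Cl)cccn23)c1)c1cccc(Cl)c1` gives 68400 nM. Compound 3 `CS(=O)(=O)c1cccc(C(=O)Nc2ccc(Cl)c(-c3nnc4c(Cl)cccn34)c2)c1` likewise gives only a limit, > 100000 nM. So compound 3 stands at the weak edge of what this assay can report, a place shared with another member of the set, as the limit of > 100000 nM in this assay, at which 2 of the 3 values shown sit, shows.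

Compound 4 `O=C(Nc1ccc(Cl)c(-c2nnc3c(Cl)cccn23)c1)c1ccccn1` differs from compound 3 in one place: pyridin-2-yl in place of 3-(methylsulfonyl)phenyl on a carbonyl carbon.

For the measured compounds named here, two measured steps touch compound 3. The step that the two limits leave unreadable from compound 1 to compound 3 cannot be read, since both ends are limits. The step of an at least 1.4-fold higher number from compound 2 to compound 3 (0.16 log units; that floor lies within the scatter) is a small one whose floor sits inside the scatter. Neither step involves pyridin-2-yl, so no direct guide exists for this change; all three measured compounds are weak inhibitors, and compound 4 is therefore expected to stay near the limit, with a number no higher from compound 3 to compound 4 (the limit leaves the size open). The estimate for compound 4 is 100000 nM, ranging from 30000 nM to 300000 nM.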

Compound 4, half-maximal inhibitory concentration: > 100000 nM
Compound 4 ended at the assay's limit; the forecaster's own chance of this, stated with the estimate: 60%; the middle value lies on the limit itself.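

In this assay, pyridin-2-yl on this carbonyl carbon leaves compound 4 at a limit of the assay, making it the third of these groups to end there: the limit of > 100000 nM in this assay, at which 3 of the 4 values shown sit. For the compounds shown here, the one readable step is an at least 1.4-fold higher number from compound 2 to compound 4 (0.16 log units; that floor lies within the scatter), while the steps from compound 1 and compound 3 to compound 4 join two limits and cannot be read. Replacing 3-(methylsulfonyl)phenyl with the smaller pyridin-2-yl, which has a hetero atom in its ring, thus does not bring a measurable number, and among the four compounds only compound 2 gives one, 68400 nM.

On these data alone, how far past the limit compound 1, compound 3 and compound 4 lie stays open, and so does whether these three differ at all. Also open, as far as these compounds go, is whether a carboxylic acid or a longer chain carrying an amine at this place would give a lower number.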